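Moving the basic nitrogen along the side chain

The source may report more compounds than this note shows. Statements on the series, on what has been measured and on what is new or still open speak of the compounds shown alone.

Measured so far in an assay on isolated protein for binding affinity to Neuropeptide Y receptor type 1 (Homo sapiens); on this read-out lower numbers stand for stronger inhibition and higher numbers for weaker inhibition:
compound 1 `Clc1ccc(OCc2nc3c(OCCC4CCNCC4)cccc3n2CCCC2CCCNC2)cc1`: 7 nM
compound 2 `Clc1ccc(OCc2nc3ccccc3n2CCCC2CCNCC2)cc1`: 980 nM
compound 3 `Clc1ccc(OCc2nc3ccccc3n2CCN2CCCCC2)cc1`: > 100000 nM

Compound 2 `Clc1ccc(OCc2nc3ccccc3n2CCCC2CCNCC2)cc1` gives 980 nM in this assay. Of the two numbers available, compound 2 stands highest; its nearest neighbour, compound 1, sits far below it, beyond the scatter. For compound 3 the assay gives only a limit, > 100000 nM (the limit of > 100000 nM in this assay, at which 1 of the 3 values shown sits), not a number. Going by the values given here, the one measured step that bears on the change now considered is an at least 100-fold higher number from compound 2 to compound 3 (2.00 log units; beyond the scatter), in which the piperidine ring becomes attached through its nitrogen on a shorter chain.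

Compound 4 `Clc1ccc(OCc2nc3ccccc3n2CCCN2CCCCC2)cc1` differs from compound 2 by piperidin-1-yl in place of piperidin-4-yl on a saturated chain carbon, three bonds along the chain from an aromatic nitrogen. The ring is again attached through its nitrogen, while the chain keeps the length of compound 2. Given the step from compound 2 to compound 3, a large rise is expected, though with the chain unchanged it may stop short of that limit. For compound 4 the expected value in this assay is 20000 nM, within 3000 nM to 150000 nM, a step of a 20-fold higher number from compound 2 to compound 4 (1.31 log units; beyond the scatter).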

Compound 4, inhibition constant: 7020 nM
For compound 4 the middle estimate is 2.8-fold (0.45 log units) above the measured one; the range from low to high includes it.
By their numbers in this assay, from the lowest: compound 1; then compound 2; then compound 4. At a limit, above all of these: compound 3.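

In this assay, moving the attachment of the piperidine ring to its nitrogen, which removes the ring's hydrogen-bond donor, gives a 7.2-fold higher number from compound 2 to compound 4 (0.86 log units; beyond the scatter) when the chain length is held, so this change alone is modest. Extending the chain while keeping the piperidin-1-yl group gives an at least 14-fold lower number from compound 3 to compound 4 (1.15 log units; beyond the scatter), which shows that chain length also matters and that the earlier large step did not come from the attachment alone. The size of this second step is bounded on one side only, since compound 3 stands at a limit and not at a number: the limit of > 100000 nM in this assay, at which 1 of the 4 values shown sits.

From the compounds shown here alone, it remains open whether a longer chain carrying piperidin-1-yl would bring the number down further. Going by these compounds, it is also open whether an open-chain amine such as dimethylamino would behave as the piperidin-1-yl group does at this position.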